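Replacing 2-chlorophenyl with pyridin-2-yl: the expected effect

This account rests on a few compounds, and the source may have more. Where it says the series, first, only, none or still open, it means among the compounds named here.

Measured in a functional assay on SGC-7901 cells (Homo sapiens) for antiproliferative activity, read by MTT assay, with a stated time of 48 h; a lower number here means a stronger inhibitor, a higher number a weaker inhibitor:
- compound 1 `Cc1ccc(-c2nnc(SCc3ccc(Cl)nc3)o2)cc1`: 3.62 ug/mL
- compound 2 `Fc1ccc(-c2nnc(SCc3ccc(Cl)nc3)o2)cc1`: 3.67 ug/mL
- compound 3 `Clc1ccc(CSc2nnc(-c3ccccc3Cl)o2)cn1`: 13.5 ug/mL

Compound 3 has the highest number of the three, making it the weakest inhibitor so far. Compound 1 and compound 2 cannot be told apart, with a 1.0-fold higher number from compound 1 to compound 2 (0.01 log units; within the scatter).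

The next structure, compound 4 `Clc1ccc(CSc2nnc(-c3ccccn3)o2)cn1`, keeps the shared core and changes one group: pyridin-2-yl in place of 2-chlorophenyl on an aromatic carbon. Among the measured compounds shown here, no measured step makes this exact swap. The closest evidence comes from changes at the same place: a 3.7-fold higher number from compound 1 to compound 3 (0.57 log units; beyond the scatter), and a 3.7-fold higher number from compound 2 to compound 3 (0.57 log units; beyond the scatter). These modest steps show that a change here can move the number, but three compounds are thin evidence, and none carries pyridin-2-yl.

In this assay, a small shift towards a lower number is therefore expected, not clearly beyond the scatter: a 1.5-fold lower number from compound 3 to compound 4 (0.18 log units; within the scatter). Compound 4 is estimated at 9 ug/mL, with an expected range from 3.5 ug/mL to 25 ug/mL.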

Compound 4, half-maximal inhibitory concentration: 12.6 ug/mL
Compound 4: middle estimate off by 1.4-fold (0.15 log units), on the low side, within the range that was stated.
By their numbers in this assay, from the lowest: compounds 1 and 2 (each within the scatter of the next); then compounds 4 and 3 (each within the scatter of the next).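

In this assay the swap of 2-chlorophenyl for pyridin-2-yl gives a 1.1-fold lower number from compound 3 to compound 4 (0.03 log units; within the scatter) and so leaves the two groups indistinguishable at this position, although the entering ring carries a nitrogen and a hydrogen-bond acceptor and the leaving one a chlorine. The gap to the 4-substituted phenyl compounds remains, with a 3.4-fold higher number from compound 2 to compound 4 (0.54 log units; beyond the scatter) and a 3.5-fold higher number from compound 1 to compound 4 (0.54 log units; beyond the scatter) showing that it is not tied to 2-chlorophenyl alone. No measurement shown here accounts for these results.

The compounds shown leave open whether moving the chlorine, as in 4-chlorophenyl, would close that gap. They also leave open how this position responds to a group without an aromatic ring, such as an amine or a longer alkyl chain.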